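A few compounds are considered here, and "the series" means these few. Any claim that something is new, unique, unknown or untested is made for them only; others in the source may bear on it.

Two urea compounds have been measured in an ADME assay on the whole organism with Oryza sativa as the target, tested at 0.1 uM; a lower number here means a stronger effect, a higher number a weaker effect of the compound at the concentration tested. Compound 1 `C[C@H](NC(=O)Nc1ccc(C(C)(C)C)cc1)c1ccccc1` gives 100% in this assay. Compound 2 `CCCCCc1ccc(NC(=O)N[C@@H](C)c2ccccc2)cc1` gives 98% in this assay. Among the compounds with values here, the single measured step is a number 2 percentage points lower from compound 1 to compound 2 (within the scatter), so compound 2 stands within the usual scatter of compound 1, and the two numbers cannot be told apart.

The new compound 3 `C[C@H](NC(=O)Nc1ccc(C(F)(F)F)cc1)c1ccccc1` differs from compound 2 at one place: trifluoromethyl in place of pentyl on an aromatic carbon. Within the data shown here, the one measured step bears on this change only loosely. It also exchanged one group for another on the same aromatic carbon, and it moved the read-out by a number 2 percentage points lower from compound 1 to compound 2 (within the scatter), a shift within the scatter. Among the measured compounds shown here, nothing measured so far shows that exchanging the group at this place moves the number beyond the scatter, and both measured values sit close to each other. A step of no change at the digits printed from compound 2 to compound 3 (within the scatter) is therefore expected, which means no step beyond the scatter. Compound 3 is estimated to give 98% in this assay, with a range from 88% to 100%.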

Compound 3, a percentage reported as activity, at one concentration (the size of the read-out at that concentration, not a potency): 94%
For compound 3 the middle estimate is 4 percentage points above the measured one; the measured number falls inside the stated range.
By their numbers in this assay, from the lowest: compounds 3, 2 and 1 (each within the scatter of the next).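

In this assay, the place on the aromatic carbon, para to a large group, now carries a third kind of group: trifluoromethyl, which brings fluorine where tert-butyl and pentyl hold only carbon. Even so, the result is a number 4 percentage points lower from compound 2 to compound 3 (within the scatter) and a number 6 percentage points lower from compound 1 to compound 3 (within the scatter), so trifluoromethyl cannot be told apart from either of the groups measured before it, and these three compounds give no sign that the choice among these groups matters at this concentration. No supporting data are available to explain why these exchanges leave the read-out within the scatter.

It remains open whether a group of a different kind at this place, such as an amine or a carboxylic acid, would move the number beyond the scatter, since the three groups shown all lack hydrogen-bond donors and acceptors and carry no net charge. Also open, going by these compounds, is whether changes elsewhere on the shared core, for example on the other aromatic ring or at the urea, would separate compounds in a way that exchanges at this place have yet to do.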